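Swapping piperazin-1-yl for a (6-aminohexyl)amino group

This account rests on a few compounds, and the source may have more. Where it says the series, first, only, none or still open, it means among the compounds named here.

Among the measured compounds shown here, compound 3 `O=C(NCc1ccc(F)cc1)c1nc(Br)c2cccnc2c1N1CCNCC1` gives 6000 nM in a functional assay on SK-BR-3 cells (Homo sapiens) for cytotoxicity, read by MTT assay, with a stated time of 72 h (a lower number here means a stronger inhibitor, a higher number a weaker inhibitor), and holds the only true number so far among the compounds sharing this core. Compound 1 `Nc1cccc(Nc2c(C(=O)NCc3ccc(F)cc3)nc(Br)c3cccnc23)c1` gives > 10000 nM in this assay as a limit of the assay and not a number. For compound 2 `NCCCNc1c(C(=O)NCc2ccc(F)cc2)nc(Br)c2cccnc12` the entry reads "not determined" (no result reported) and offers no guide.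

Compound 4 `NCCCCCCNc1c(C(=O)NCc2ccc(F)cc2)nc(Br)c2cccnc12` has not yet been measured and differs from compound 3 in one place: (6-aminohexyl)amino in place of piperazin-1-yl on an aromatic carbon on an aromatic carbon para to a bromo group. The group that enters has no ring, whereas the one that leaves has a six-membered non-aromatic ring.

For the measured compounds named here, one measured step bears on this position: piperazin-1-yl in place of (3-aminophenyl)amino gave an at least 1.6-fold lower number from compound 1 to compound 3 (0.22 log units; that floor lies within the scatter) and so shows no firm effect of a change there. On that thin evidence, and starting from compound 3 at 6000 nM as the only anchor, no step beyond the scatter is expected in this assay in either direction. The estimated change is a 1.3-fold lower number from compound 3 to compound 4 (0.12 log units; within the scatter) and is no more than a cautious guess. Compound 4 is expected at 4500 nM with an estimated range from 1200 nM to 14000 nM and could also return only a limit.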

Compound 4, half-maximal inhibitory concentration: 3000 nM
Estimate against measurement, compound 4: 1.5-fold (0.18 log units) above, and the stated range covers the measured number.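

Replacing piperazin-1-yl with the open-chain (6-aminohexyl)amino group gives a 2.0-fold lower number from compound 3 to compound 4 (0.30 log units; within the scatter), so in this assay the six-membered non-aromatic ring of compound 3 can be given up at this aromatic carbon without a change that stands clear of the scatter. Among the compounds shown here, the comparison with compound 1 adds the first step at this position that is beyond the scatter: with 6-aminohexyl in place of 3-aminophenyl on the nitrogen, the result is an at least 3.3-fold lower number from compound 1 to compound 4 (0.52 log units; beyond the scatter), although this gain is only modest. Compound 1 gives > 10000 nM, which is a limit of the assay and not a number, so this step has a floor but no exact size: the limit of > 10000 nM in this assay, at which 1 of the 4 values shown sits.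

The steps involving compound 2 cannot be read, which leaves no usable comparison between chains of different length carrying a terminal amine. As far as these compounds go, it remains open whether a longer chain, a chain ending in a carboxylic acid instead of the amine, or an N-methylpiperazin-1-yl group at this carbon would move the number beyond the scatter from compound 4.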